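The compounds below may be only part of what the source reports. "The series", "measured", "known", "first", "only" and "open" are said of these compounds alone.

Measured compounds:
Compound 1, `COc1ccc(-c2[nH]c3ccccc3c2/C=C(\C#N)S(=O)(=O)c2ccccc2)cc1`: 1500 nM
Compound 2, `COc1ccc(-c2[nH]c3ccc(OC)cc3c2/C=C(\C#N)S(=O)(=O)c2ccccc2)cc1`: 4300 nM
Compound 3, `CC(=O)/C(=C\c1c(-c2ccccc2)[nH]c2ccccc12)S(=O)(=O)c1ccccc1`: 6100 nM

Three compounds share a core and were tested in a functional assay on NCI-H322M cells (Homo sapiens) for inhibition, read by sulforhodamine B assay, with a stated time of 48 h; on this read-out higher numbers stand for weaker inhibition of growth and lower numbers for stronger inhibition of growth; in it compound 1 gives 1500 nM, compound 2 gives 4300 nM and compound 3 gives 6100 nM. Compound 2 stands second highest of the three numbers. Its nearest neighbour is compound 3, whose number lies within the scatter of that of compound 2, so the two cannot be told apart; compound 1 sits further off, with a clearly lower number.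

Compound 4, `COc1ccc2[nH]c(-c3ccccc3)c(/C=C(\C#N)S(=O)(=O)c3ccccc3)c2c1`, has not yet been measured. It differs from compound 2 in one place: hydrogen in place of methoxy on an aromatic carbon.

Among the measured compounds shown here, only one measured step concerns a methoxy group, and it sits at a different place: a 2.9-fold higher number from compound 1 to compound 2 (0.46 log units; beyond the scatter), where methoxy entered on the core's own aromatic ring. For the measured compounds named here, no measured pair isolates the change from 4-methoxyphenyl to phenyl; compound 3 carries a plain phenyl but also a different group at the nitrile position, so its value alone cannot settle the question. With one loosely related step that points to methoxy raising the number, a modest fall or no change beyond the scatter is expected for the step of a 1.4-fold lower number from compound 2 to compound 4 (0.16 log units; within the scatter). Compound 4 is therefore estimated at 3000 nM, within a range from 1200 nM to 8000 nM.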

Compound 4, concentration for 50% growth inhibition: 30100 nM
Beside the measured number, compound 4's estimate is 10-fold (1.00 log units) below it; measured number above the stated range.
By their numbers in this assay, from the lowest: compound 1; then compounds 2 and 3 (each within the scatter of the next); then compound 4.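

In this assay the change from 4-methoxyphenyl to phenyl brings a 7.0-fold higher number from compound 2 to compound 4 (0.85 log units; beyond the scatter) and so clearly weaker inhibition of growth, the first sign among these compounds that the methoxy of the 4-methoxyphenyl group helps rather than merely being tolerated. The earlier methoxy step, on the core's own aromatic ring, ran the other way, with a 2.9-fold higher number from compound 1 to compound 2 (0.46 log units; beyond the scatter) when the group entered, so in these two steps the same group has opposite effects at its two places, and its value cannot be judged apart from where it sits. The data shown offer no explanation for this contrast.

Whether this step would keep its size on the core of compound 1, which has no methoxy on its own ring, remains open, since the shown step was taken with that second methoxy present. Also open, on these data alone, is whether the methoxy itself is what this place needs, or whether a hydroxyl group, an amine or a longer chain such as ethoxy would serve as well or better.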